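Moving the Acetyl Group on Compound 2

This account rests on a few compounds, and the source may have more. Where it says the series, first, only, none or still open, it means among the compounds named here.

In a functional assay on MCF7 cells (Homo sapiens) for cytotoxicity, read by MTT assay, with a stated time of 48 h (a lower number here means a stronger inhibitor, a higher number a weaker inhibitor), compound 1 `CC1(C)CCCC2=CC=C(C=O)CC[C@]21C` gives 167000 nM, while compound 2 `C=C1CCC[C@]2(C)CCC(c3cn(-c4ccc(C(C)=O)cc4)nn3)=CC[C@@]12C` gives 65400 nM, the lower of these two numbers and so the stronger result. Compound 3 `C=C1CCC[C@]2(C)CCC(c3cn(-c4ccccc4C(C)=O)nn3)=CC[C@@]12C` has the same atoms joined differently, with 2-acetylphenyl in place of 4-acetylphenyl on an aromatic nitrogen. Within the data shown here, no measured pair shows what such a change does, so in this assay the expectation is no step beyond the usual scatter, in either direction. The estimated step is a 1.1-fold higher number from compound 2 to compound 3 (0.03 log units; within the scatter). For compound 3 the expected value is 70000 nM, with an estimated range from 30000 nM to 160000 nM.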

Compound 3, half-maximal inhibitory concentration: 29900 nM
For compound 3 the middle estimate is 2.3-fold (0.37 log units) above the measured one; measured number outside the range, below it.
By their numbers in this assay, from the lowest: compound 3; then compound 2; then compound 1.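

In this assay, the position of the acetyl group on the phenyl group carried by the aromatic nitrogen matters: 2-acetylphenyl in place of 4-acetylphenyl gives a 2.2-fold lower number from compound 2 to compound 3 (0.34 log units; beyond the scatter). Both compounds have the same atoms, so this modest step comes from how they are joined, which compound 1, differing in more than one place, could not show. Nothing available explains the step. Still open, as far as these compounds go, is whether an amine or a carboxylic acid in place of the acetyl group in 2-acetylphenyl would lower the number further or raise it.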